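Two Amides at the Limit, a Third Still Unmeasured

A few compounds are considered here, and "the series" means these few. Any claim that something is new, unique, unknown or untested is made for them only; others in the source may bear on it.

Compound 1 `CN(Cc1ccccc1)C(=O)C1CCN(C(=O)c2ccc(S(C)(=O)=O)c([N+](=O)[O-])c2)CC1`: in an assay on isolated protein for inhibition of thyroid hormone receptor alpha (Homo sapiens), read by fluorescence polarization (on this read-out higher numbers stand for weaker inhibition and lower numbers for stronger inhibition), compound 1 reaches only the limit of the assay, > 60000 nM.
Compound 2 `CC1Cc2ccccc2N1C(=O)C1CCN(C(=O)c2ccc(S(C)(=O)=O)c([N+](=O)[O-])c2)CC1`: in this assay compound 2 likewise reaches only the limit, > 60000 nM.

Compound 2 thus stands not at a number but at a limit, and the step that the two limits leave unreadable from compound 1 to compound 2 cannot be read in size or direction. The one piece of evidence is the limit of > 60000 nM in this assay, at which 2 of the 2 values shown sit, so the shared core has shown no measurable inhibition with either amine on the carbonyl carbon.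

Compound 3 `CC(C)N(C(=O)C1CCN(C(=O)c2ccc(S(C)(=O)=O)c([N+](=O)[O-])c2)CC1)C(C)C` carries the change (diisopropylamino in place of 2-methyl-2,3-dihydro-1H-indol-1-yl on a carbonyl carbon). Going by the values given here, the only steps that bear on it are the two limits, which give no readable size. Compound 3 is therefore expected to sit again at a limit, estimated as 80000 nM with a range from 40000 nM to 200000 nM. The expected step that the limit leaves unreadable from compound 2 to compound 3 is none beyond the scatter, because both values shown sit at the limit of > 60000 nM in this assay, at which 2 of the 2 values shown sit.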

Compound 3, half-maximal inhibitory concentration: > 60000 nM
Compound 3 ended at the assay's limit (the forecaster's own chance of this, stated with the estimate: 85%); the middle value lies beyond the limit too.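

Going by these compounds alone, compound 1, compound 2 and compound 3 all stop at a limit rather than a number in this assay, so no step among them can be read in size or direction: the limit of > 60000 nM in this assay, at which 3 of the 3 values shown sit.

The compounds shown leave open whether any other group on this carbonyl carbon, or any change elsewhere on the shared core, would give a readable number.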